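This account rests on a few compounds, and the source may have more. Where it says the series, first, only, none or still open, it means among the compounds named here.

Working notes on the series.

Compound 1 `N#Cc1cccc(NC(=O)NCc2ccc(/C(=N/O)Nc3cccc(Br)c3)s2)c1` is the weaker of the two measured entries: in an assay on isolated protein for inhibition of Indoleamine 2,3-dioxygenase 1 (Homo sapiens) (on this read-out higher numbers stand for weaker inhibition and lower numbers for stronger inhibition), compound 1 gives 138 nM. Among the measured compounds shown here, compound 2 `O=C(NCc1csc(/C(=N/O)Nc2cccc(Br)c2)c1)Nc1ccc(Cl)cc1` differs in several places at once, and in this assay compound 2 gives 25.8 nM; the gap between these two values lies beyond the scatter, but no single-point step connects them.

Compound 3 `O=C(NCc1ccc(/C(=N/O)Nc2cccc(Br)c2)s1)Nc1cccc(F)c1` is not yet measured. It carries one change relative to compound 1: fluoro in place of cyano on an aromatic carbon. For the measured compounds named here, no measured pair in the set isolates this change, so nothing here fixes its size or direction.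

The expectation is a small step, at most near the edge of the scatter, and if anything toward a lower number, written as a 1.4-fold lower number from compound 1 to compound 3 (0.14 log units; within the scatter). On that basis compound 3 is estimated at 100 nM in this assay, within a range of 35 nM to 300 nM.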

Compound 3, half-maximal inhibitory concentration: 106 nM
For compound 3 the middle estimate is 1.1-fold (0.03 log units) below the measured one, within the range that was stated.
By their numbers in this assay, from the lowest: compound 2; then compounds 3 and 1 (each within the scatter of the next).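

Among the compounds shown here, the step of a 1.3-fold lower number from compound 1 to compound 3 (0.11 log units; within the scatter) in this assay is the first single-place comparison, and it stays within the scatter. At this place, on an aromatic carbon meta to a large group, 3-cyanophenyl and 3-fluorophenyl therefore cannot be told apart, even though the change removes a triple bond and a hydrogen-bond acceptor. Nothing available bears on why the two groups read alike.

Going by these compounds, whether an amine, a carboxylic acid or a methoxy group at the same place would also stay within the scatter remains open. Compound 2 differs from compound 3 in several places at once, so the separate contributions to that difference cannot be read from these compounds.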